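This account rests on a few compounds, and the source may have more. Where it says the series, first, only, none or still open, it means among the compounds named here.

Compound 3 `CC[C@H]1OC(=O)[C@H](C)[C@@H](O[C@H]2C[C@@](C)(OC)[C@@H](OCCCNC(=O)COC)[C@H](C)O2)[C@H](C)[C@@H](O[C@@H]2O[C@H](C)C[C@H](N(C)C)[C@H]2O)[C@](C)(O)C[C@@H](C)CN(C)[C@H](C)[C@@H](O)[C@]1(C)O` gives the lowest of the three numbers in a physicochemical assay for lipophilicity, read by HPLC, measured as chromatographic lipophilicity, at pH 7.4 (on this read-out higher numbers stand for higher lipophilicity and lower numbers for lower lipophilicity), at 2.16. Compound 2 `CC[C@H]1OC(=O)[C@H](C)[C@@H](O[C@H]2C[C@@](C)(OC)[C@@H](O)[C@H](C)O2)[C@H](C)[C@@H](O[C@@H]2O[C@H](C)C[C@H](N(C)C)[C@H]2O)[C@](C)(O)C[C@@H](C)CN(CCCNC(=O)c2c(C)nn(C)c2Cl)[C@H](C)[C@@H](O)[C@]1(C)O` gives 2.2 and compound 1 `CC[C@H]1OC(=O)[C@H](C)[C@@H](O[C@H]2C[C@@](C)(OC)[C@@H](O)[C@H](C)O2)[C@H](C)[C@@H](O[C@@H]2O[C@H](C)C[C@H](N(C)C)[C@H]2O)[C@](C)(O)C[C@@H](C)CN(CCCNC(=O)C2CCC2)[C@H](C)[C@@H](O)[C@]1(C)O` gives 2.31, both within the scatter of compound 3. Compound 4 `CC[C@H]1OC(=O)[C@H](C)[C@@H](O[C@H]2C[C@@](C)(OC)[C@@H](OCCCNC(=O)C3CCC3)[C@H](C)O2)[C@H](C)[C@@H](O[C@@H]2O[C@H](C)C[C@H](N(C)C)[C@H]2O)[C@](C)(O)C[C@@H](C)CN(C)[C@H](C)[C@@H](O)[C@]1(C)O` is compound 3 with cyclobutyl in place of methoxymethyl on a carbonyl carbon. For the measured compounds named here, the one measured step between these compounds, a number 0.11 log units lower from compound 1 to compound 2 (within the scatter), also exchanges a group on a carbonyl carbon, yet no measured pair exchanges methoxymethyl for cyclobutyl, so it bears only loosely on the present step. For compound 4 the expected step is a number 0.44 log units higher from compound 3 to compound 4 (beyond the scatter), upward, and of a size that may just clear the scatter. The estimate for compound 4 in this assay is therefore 2.6, within 2.2 to 3.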

Compound 4, distribution coefficient: 2.62
The estimate for compound 4 lay 0.02 log units below the measured number, within the range that was stated.
By their numbers in this assay, from the lowest: compounds 3, 2 and 1 (each within the scatter of the next); then compound 4.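

In this assay, the exchange of methoxymethyl for cyclobutyl on a carbonyl carbon gives a number 0.46 log units higher from compound 3 to compound 4 (beyond the scatter), which shows that the group at this position can move the number beyond the scatter. The exchange removes a hydrogen-bond acceptor and adds a four-membered ring of carbon only, but nothing available explains the step. The compounds shown do not separate the ring from the loss of the oxygen. An open-chain butyl or a cyclopropyl at this carbonyl carbon would bear on that question, as would an ethoxymethyl.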